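The source may report more compounds than this note shows. Statements on the series, on what has been measured and on what is new or still open speak of the compounds shown alone.

Of the compounds shown here, two have been tested for cytotoxicity. Compound 1 `Cc1c(NCc2nc3cc([N+](=O)[O-])ccc3[nH]2)c(=O)n(-c2ccccc2)n1C` gives 44000 nM in a functional assay on HCT-116 cells (Homo sapiens) for cytotoxicity, read by MTT assay; a higher number here means a weaker inhibitor, a lower number a stronger inhibitor. Compound 2 `O=[N+]([O-])c1ccc2[nH]c(CNc3c([N+](=O)[O-])ccc4ncccc34)nc2c1` gives 256000 nM in this assay, which is the higher of the two numbers; its gap to compound 1 lies beyond the usual scatter, so compound 2 is the weaker of the two. Both are weak inhibitors on this scale.

The next compound to be examined is compound 3 `O=[N+]([O-])c1ccc2ncccc2c1NCc1nc2ccccc2[nH]1`. It differs from compound 2 in a single place: hydrogen in place of nitro on an aromatic carbon. The nitro group that leaves sat on the six-membered aromatic ring of carbon only within the fused system of two rings, and a hydrogen atom takes its place; the rest of the structure is kept.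

Going by the values given here, no measured pair in this set shows the effect of such a change, so the expectation can rest only on the weak starting point of compound 2. The step from compound 2 to compound 3 is expected to be small, a 1.3-fold lower number from compound 2 to compound 3 (0.11 log units; within the scatter), and need not go beyond the scatter in either direction. Compound 3 is therefore estimated at 200000 nM, with a range from 60000 nM to 600000 nM.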

Compound 3, half-maximal inhibitory concentration: 204000 nM
For compound 3 the middle estimate is 1.0-fold (0.01 log units) below the measured one; low and high end bracket the measured number.
By their numbers in this assay, from the lowest: compound 1; then compounds 3 and 2 (each within the scatter of the next).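

In this assay, going by these compounds alone, replacing the nitro group on the six-membered aromatic ring of carbon only with a hydrogen atom gives a 1.3-fold lower number from compound 2 to compound 3 (0.10 log units; within the scatter) and so provides the first direct reading of a change at this place. The step lies within the scatter, so in this pair the loss of the nitro group, with its three heavy atoms, produces no measurable shift, and the number stays high on this weak scale. No measured property of either compound bears on this result, and nothing can be said about what lies behind it.

The compounds shown leave open whether another group at this same place, such as an amine, a carboxylic acid or a methoxy group, would move the number beyond the scatter, as only nitro and hydrogen are compared here. They also leave open whether removing the nitro group that compound 3 keeps would be as small a change, or whether the same exchange would give a similar result in a compound with another core.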